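This account rests on a few compounds, and the source may have more. Where it says the series, first, only, none or still open, it means among the compounds named here.

Measured compounds:
compound 1 `CCCCCCOc1ccc(C(CC(=O)O)c2ccccc2)cc1` — in a functional assay on HEK293 cells for agonist activity at Free fatty acid receptor 1 (Homo sapiens), read by calcium flux (a lower number here means that less compound is needed, a higher number that more compound is needed for the effect), compound 1 gives 2.88 uM
compound 2 `O=C(O)CC(c1ccccc1)c1ccc(OCCCC(F)(F)F)cc1` — compound 2 gives 3.16 uM
compound 3 `C/C=C/COc1ccc(C(CC(=O)O)c2ccccc2)cc1` — compound 3 gives 2.71 uM

For the measured compounds named here, compound 3 has the lowest of the three numbers, but its steps to the others, a 1.1-fold lower number from compound 1 to compound 3 (0.03 log units; within the scatter) and a 1.2-fold lower number from compound 2 to compound 3 (0.07 log units; within the scatter), stay within the scatter, so no compound stands apart. Compound 4 `COCCCOc1ccc(C(CC(=O)O)c2ccccc2)cc1` differs from compound 3 by 2-methoxyethyl in place of prop-1-en-1-yl on a saturated chain carbon bound to an oxygen on an aromatic ring. Both measured changes at this place, from pentyl and from 3,3,3-trifluoropropyl, stayed within the scatter, as did a 1.1-fold higher number from compound 1 to compound 2 (0.04 log units; within the scatter) on the same chain. Nothing among these compounds points to a shift beyond the scatter, so for compound 4 a step of a 1.1-fold higher number from compound 3 to compound 4 (0.03 log units; within the scatter) is expected, and its number in this assay is estimated at 2.9 uM, between 1.4 uM and 6 uM.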

Compound 4, concentration for half-maximal effect: 7.58 uM
For compound 4 the middle estimate is 2.6-fold (0.42 log units) below the measured one; the measured number lies above the stated range.
By their numbers in this assay, from the lowest: compounds 3, 1 and 2 (each within the scatter of the next); then compound 4.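

Pentyl, 3,3,3-trifluoropropyl and prop-1-en-1-yl on this saturated chain carbon had stayed within the scatter of one another, but 2-methoxyethyl gives the first steps beyond it (a 2.8-fold higher number from compound 3 to compound 4 (0.45 log units; beyond the scatter)) (a 2.4-fold higher number from compound 2 to compound 4 (0.38 log units; beyond the scatter)) (a 2.6-fold higher number from compound 1 to compound 4 (0.42 log units; beyond the scatter)). Among these four compounds, only compound 4 has a hydrogen-bond acceptor in the group at this place, yet a single compound cannot tie the step to that oxygen. No measurement shown explains the step. Going by these compounds, it remains open whether an amine, a hydroxyl or a longer ether chain here would also raise the number.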